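A few compounds are considered here, and "the series" means these few. Any claim that something is new, unique, unknown or untested is made for them only; others in the source may bear on it.

Four analogues built on one shared core are considered here. Compound 1 `C=C1CC[C@@H]2[C@](C)(CO)[C@H](O)CC[C@@]2(C)[C@@H]1CC(Sc1ccc(C)cc1)C1=CCOC1=O` and compound 2 `C=C1CC[C@@H]2[C@](C)(CO)[C@H](O)CC[C@@]2(C)[C@@H]1CC(Sc1ccc([N+](=O)[O-])cc1)C1=CCOC1=O` carry a substituted phenylsulfanyl arm directly on the side chain, while compound 3 `C=C1CC[C@@H]2[C@](C)(CO)[C@H](O)CC[C@@]2(C)[C@@H]1C/C=C1/C(=O)OC[C@H]1OC(=O)CCCSc1ccc([N+](=O)[O-])cc1` and compound 4 `C=C1CC[C@@H]2[C@](C)(CO)[C@H](O)CC[C@@]2(C)[C@@H]1C/C=C1/C(=O)OC[C@H]1OC(=O)CCCSc1ccc(C)cc1` carry the corresponding arm at the end of an ester chain attached to the lactone portion. In a functional assay on PC-3 cells (Homo sapiens) for inhibition, read by MTT assay, with a stated time of 48 h (on this read-out higher numbers stand for weaker inhibition and lower numbers for stronger inhibition), compound 1 gives 29000 nM. In this assay compound 2 gives 17000 nM, and the step of a 1.7-fold higher number from compound 2 to compound 1 (0.23 log units; within the scatter) comes from the change (methyl in place of nitro on an aromatic carbon). In this assay compound 3 gives 17000 nM, which is level with compound 2 at the digits read; the difference between the core of compound 3 and that of compound 2 is not broken down here.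

Compound 4 is obtained from compound 3 by the change (methyl in place of nitro on an aromatic carbon), the same change that turned compound 2 into compound 1. Since that earlier step stayed within the scatter, the step from compound 3 to compound 4 is expected to be of similar size, and compound 4 is estimated to land near 25000 nM in this assay, with a likely range from 10000 nM to 60000 nM. The expected step for compound 4 is a 1.5-fold higher number from compound 3 to compound 4 (0.17 log units; within the scatter), resting on the measured step from compound 2 to compound 1. For compound 4 the estimate therefore rests on two measured compounds only, and a wider deviation cannot be ruled out.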

Compound 4, half-maximal inhibitory concentration: 16000 nM
For compound 4 the middle estimate is 1.6-fold (0.19 log units) above the measured one; low and high end bracket the measured number.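

In this assay, methyl in place of nitro on the aromatic carbon gives a 1.1-fold lower number from compound 3 to compound 4 (0.03 log units; within the scatter), so on the core with the ester chain, this change leaves the number within the usual scatter of repeated measurements. Among the compounds shown here, the step on this core does not differ from the earlier one on the core with the arm directly on the side chain by more than two such steps can scatter: the same change on two cores in this assay, a 1.7-fold higher number (0.23 log units; within the scatter) from compound 2 to compound 1 and a 1.1-fold lower number (0.03 log units; within the scatter) from compound 3 to compound 4, 1.8-fold (0.26 log units) apart, within the scatter of two such steps This shows that, across these two cores, the exchange of 4-nitrophenyl for 4-methylphenyl behaves alike in that neither step can be told from scatter, but it does not show that the change has any real effect on either core or that a real effect would carry over, since two small steps are a weak test of transfer and only two pairs are available.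

The compounds shown leave open whether an amine or a carboxylic acid on the same aromatic carbon would move the number beyond the scatter. They also leave open whether a longer chain in the ester arm would alter the step seen for this change.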